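Shifting the aryl amide halogen on a shared flavonol core

The compounds below may be only part of what the source reports. "The series", "measured", "known", "first", "only" and "open" are said of these compounds alone.

Three close analogues have been tested in a functional assay on MDA-MB-231 cells (Homo sapiens) for antiproliferative activity, read by CCK-8 assay, with a stated time of 72 h; a lower number here means a stronger inhibitor, a higher number a weaker inhibitor. Compound 1 `O=C(Nc1cccc(-c2oc3cc(-c4ccc(F)cc4)ccc3c(=O)c2O)c1)c1ccc(F)cc1` gives 16000 nM. Compound 2 `Cc1ccc(C(=O)Nc2cccc(-c3oc4cc(-c5ccc(F)cc5)ccc4c(=O)c3O)c2)cc1` gives 4350 nM, and the change is a 3.7-fold lower number from compound 1 to compound 2 (0.57 log units; beyond the scatter). Compound 3 `O=C(Nc1cccc(-c2oc3cc(-c4ccc(F)cc4)ccc3c(=O)c2O)c1)c1ccc(Cl)cc1` gives 12800 nM; here a 1.3-fold lower number from compound 1 to compound 3 (0.10 log units; within the scatter), while a 2.9-fold higher number from compound 2 to compound 3 (0.47 log units; beyond the scatter). Compound 3 therefore sits second highest of the three numbers, close to compound 1 and clearly apart from compound 2.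

Compound 4 `O=C(Nc1cccc(-c2oc3cc(-c4ccc(F)cc4)ccc3c(=O)c2O)c1)c1ccc(F)cc1F` differs from compound 3 by 2,4-difluorophenyl in place of 4-chlorophenyl on a carbonyl carbon. Among the compounds with values here, the one comparison of two halogens, compound 1 to compound 3, stayed within the scatter, and no measured step tells about a second fluoro. The expectation is that a 1.1-fold higher number from compound 3 to compound 4 (0.04 log units; within the scatter), so compound 4 is estimated at 14000 nM, within 5000 nM to 40000 nM.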

Compound 4, half-maximal inhibitory concentration: 11200 nM
Compound 4: the middle estimate sits 1.3-fold (0.10 log units) above what was measured, within the range that was stated.
By their numbers in this assay, from the lowest: compound 2; then compounds 4, 3 and 1 (each within the scatter of the next).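

A second fluoro on this ring leaves the number in this assay within the scatter (a 1.4-fold lower number from compound 1 to compound 4 (0.15 log units; within the scatter)), and the same holds for 2,4-difluorophenyl in place of 4-chlorophenyl (a 1.1-fold lower number from compound 3 to compound 4 (0.06 log units; within the scatter)). The 4-methylphenyl amide stays apart from this difluoro analogue as well (a 2.6-fold higher number from compound 2 to compound 4 (0.41 log units; beyond the scatter)), so among these four compounds only the methyl compound stands out. No evidence is available to explain this difference. The compounds shown leave open whether an ethyl, a methoxy or an amine on this ring would track the methyl or the halogens.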